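Lengthening methyl to propyl on compound 3

The compounds below may be only part of what the source reports. "The series", "measured", "known", "first", "only" and "open" are said of these compounds alone.

In a physicochemical assay for solubility, read by spectrophotometry, in phosphate buffer, with a stated time of 18 h, at pH 7.4 (a lower number here means a less soluble compound, a higher number a more soluble compound), compound 1 (`CCc1ccc(-c2nc3c(c(C)nn3-c3ccccc3)c(-c3ccccc3OC(F)(F)F)c2C#N)cc1`) gives 9900 nM, compound 2 (`C#Cc1ccccc1-c1c(C#N)c(-c2ccc(CC)cc2)nc2c1c(C)nn2-c1ccccc1`) gives 46000 nM and compound 3 (`Cc1ccc(-c2nc3c(c(C)nn3-c3ccccc3)c(-c3ccccc3O)c2C#N)cc1`) gives 26000 nM. The value of compound 3 lies within the scatter of that of compound 2 and beyond the scatter above that of compound 1. Compound 4 (`CCCc1ccc(-c2nc3c(c(C)nn3-c3ccccc3)c(-c3ccccc3O)c2C#N)cc1`) differs from compound 3 by ethyl in place of hydrogen on a saturated chain carbon bound to an aromatic carbon, turning 4-methylphenyl into 4-propylphenyl. Going by the values given here, no measured step touches this chain. The only one, a 4.6-fold higher number from compound 1 to compound 2 (0.67 log units; beyond the scatter), swaps trifluoromethoxy for ethynyl elsewhere and serves merely as a gauge of size. A smaller step toward a lower number is expected, estimated as a 1.6-fold lower number from compound 3 to compound 4 (0.21 log units; within the scatter). For compound 4 the estimate is 16000 nM, with an expected range from 6500 nM to 34000 nM.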

Compound 4, solubility: 6500 nM
Estimate against measurement, compound 4: 2.5-fold (0.39 log units) above; measured number inside the range.
By their numbers in this assay, from the lowest: compounds 4 and 1 (each within the scatter of the next); then compounds 3 and 2 (each within the scatter of the next).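

Turning 4-methylphenyl into 4-propylphenyl gives the first measured step at this saturated chain carbon bound to an aromatic carbon. In this assay the number falls, a 4.0-fold lower number from compound 3 to compound 4 (0.60 log units; beyond the scatter), so this position does respond to ethyl in place of hydrogen. Nothing available here explains this fall. The compounds shown leave open whether a longer chain such as butyl would take the number further down, or whether a carboxylic acid or an amine at the end of the chain would reverse the fall. From the compounds shown here alone, whether the same change would act alike with trifluoromethoxy or ethynyl in place of the hydroxyl group also stays open.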